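A few compounds are considered here, and "the series" means these few. Any claim that something is new, unique, unknown or untested is made for them only; others in the source may bear on it.

Measured compounds:
Compound 1 `CC(C)C(c1nnc[nH]1)c1ccc(-c2ccc3cccc(F)c3c2)[nH]c1=O`: 12 nM
Compound 2 `CC(C)C(Nc1nccs1)c1ccc(-c2ccc3cccc(F)c3c2)[nH]c1=O`: 9.4 nM
Compound 3 `CCn1ncc2c(F)cc(-c3ccc(C(CC)(CC)c4nnc(C)[nH]4)c(=O)[nH]3)cc21`: 34 nM

In an assay on CHO cells for displacement of a labelled ligand from prostaglandin E2 receptor EP3 subtype (Homo sapiens), read by radioligand binding (a lower number here means a stronger inhibitor, a higher number a weaker inhibitor), compound 3 gives the highest of the three numbers; its gaps to compound 1 and to compound 2 both lie beyond the scatter, so it is the weakest inhibitor here. Compound 4 `CCn1ncc2c(F)cc(-c3ccc(C(CC)(CC)c4ncn(C)n4)c(=O)[nH]3)cc21` keeps the core of compound 3 and differs only in 1-methyl-1H-1,2,4-triazol-3-yl in place of 5-methyl-4H-1,2,4-triazol-3-yl on a saturated chain carbon bound to an aromatic carbon and two saturated chain carbons. For the measured compounds named here, the one measured step at the group on the saturated chain carbon, a 1.3-fold lower number from compound 1 to compound 2 (0.11 log units; within the scatter), swapped the whole group and stayed within the scatter. Going by the values given here, no measured step tests moving a methyl on a triazole, so the change in compound 4 is expected to stay within the scatter: a 1.0-fold higher number from compound 3 to compound 4 (0.01 log units; within the scatter). Compound 4 is estimated at 35 nM, between 14 nM and 90 nM.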

Compound 4, inhibition constant: 39 nM
Beside the measured number, compound 4's estimate is 1.1-fold (0.05 log units) below it; the range from low to high includes it.
By their numbers in this assay, from the lowest: compounds 2 and 1 (each within the scatter of the next); then compounds 3 and 4 (each within the scatter of the next).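

Moving the methyl on the triazole gives a 1.1-fold higher number from compound 3 to compound 4 (0.06 log units; within the scatter) in this assay. The group that enters has no hydrogen-bond donor, while the one that leaves has one, so in this pair the binding number holds without a donor on this ring. No measurement given here explains why the number holds. The compounds shown leave open whether the triazole itself is needed at the saturated chain carbon, since an amine or a carboxylic acid in its place on the core of compound 3 is not among them.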